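Adding a Phenyl to the Hydroxymethyl Arm of Compound 3

This account rests on a few compounds, and the source may have more. Where it says the series, first, only, none or still open, it means among the compounds named here.

Compound 3 `N#Cc1ccn2c(-c3ccccc3)c(-c3ccccc3)c(CO)c2c1` carries a hydroxymethyl group on the shared core; in an assay for inhibition of Polyunsaturated fatty acid lipoxygenase ALOX15 (Oryctolagus cuniculus) (on this read-out higher numbers stand for weaker inhibition and lower numbers for stronger inhibition), compound 3 gives 34000 nM. Compound 2 `Cc1ccc(S(=O)(=O)Oc2c(-c3ccccc3)c(-c3ccccc3)n3ccc(C#N)cc23)cc1`, which has a ((4-methylphenyl)sulfonyl)oxy group at that place, gives 25000 nM in this assay, and the step of a 1.4-fold higher number from compound 2 to compound 3 (0.13 log units; within the scatter) means the two numbers cannot be told apart. Compound 1 `COc1ccccc1-c1c(-c2ccccc2)c(-c2ccccc2)n2ccc(C#N)cc12` has "not determined" (no result reported) in this assay. Compound 4 `N#Cc1ccn2c(-c3ccccc3)c(-c3ccccc3)c(C(O)c3ccccc3)c2c1` differs from compound 3 by phenyl in place of hydrogen on a saturated chain carbon bound to an aromatic carbon and an oxygen on a saturated carbon. Within the data shown here, no measured step adds a phenyl in this way; the only measured step, a 1.4-fold higher number from compound 2 to compound 3 (0.13 log units; within the scatter), stayed within the scatter, so no shift beyond the scatter is expected in this assay, although nothing measured anchors that guess firmly. Compound 4 is therefore expected to give 30000 nM, in a range from 10000 nM to 100000 nM, an expected step of a 1.1-fold lower number from compound 3 to compound 4 (0.05 log units; within the scatter).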

Compound 4, half-maximal inhibitory concentration: 48000 nM
For compound 4 the middle estimate is 1.6-fold (0.20 log units) below the measured one, within the range that was stated.
By their numbers in this assay, from the lowest: compounds 2, 3 and 4 (each within the scatter of the next).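

Adding a whole phenyl to the hydroxymethyl arm leaves the reading in this assay unchanged within error, giving a 1.4-fold higher number from compound 3 to compound 4 (0.15 log units; within the scatter). Replacing the ((4-methylphenyl)sulfonyl)oxy group with hydroxy(phenyl)methyl likewise gives a 1.9-fold higher number from compound 2 to compound 4 (0.28 log units; within the scatter), so all three groups at this place now lie within the scatter of one another. No evidence is available to explain this flat result.

Going by these compounds, it remains open whether any group here can shift the number beyond the scatter. An amine or a carboxylic acid at this place would test that.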